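The source may report more compounds than this note shows. Statements on the series, on what has been measured and on what is new or still open speak of the compounds shown alone.

In a functional assay on PC-3 cells (Homo sapiens) for inhibition, read by MTT assay, with a stated time of 48 h (a higher number here means a weaker inhibitor, a lower number a stronger inhibitor), compound 1 `COc1ccc(CN(c2cc(OC)c(OC)c(OC)c2)S(=O)(=O)c2ccccc2)cc1` gives > 50000 nM, which is a limit of the assay and not a number. Compound 2 `COc1ccc(CN(c2cc(OC)c(OC)c(OC)c2)S(=O)(=O)c2ccc(OC)c(OC)c2)cc1`, by contrast, reads 20100 nM. Compound 3 `COc1ccc(CN(c2cc(OC)c(OC)c(OC)c2)S(=O)(=O)c2c(C)cc(C)cc2C)cc1` differs from compound 1 as follows: 2,4,6-trimethylphenyl in place of phenyl on a sulfonyl sulfur. For the measured compounds named here, compound 2 supplies the only measured step at this place, an at least 2.4-fold lower number from compound 1 to compound 2 (0.39 log units; beyond the scatter), which exchanges phenyl for 3,4-dimethoxyphenyl on a sulfonyl sulfur and lies beyond the scatter. A step of similar size towards a lower number in this assay is therefore expected, an estimated at least 4.1-fold lower number from compound 1 to compound 3 (0.61 log units; beyond the scatter). The expected value for compound 3 is 12000 nM, with an estimated range of 1000 nM to 50000 nM.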

Compound 3, half-maximal inhibitory concentration: 14800 nM
Estimate against measurement, compound 3: 1.2-fold (0.09 log units) below; the range from low to high includes it.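

In this assay, a second kind of substituted ring on the sulfonyl sulfur also lowers the number, with 2,4,6-trimethylphenyl in place of phenyl giving an at least 3.3-fold lower number from compound 1 to compound 3 (0.52 log units; beyond the scatter). Exchanging 3,4-dimethoxyphenyl for 2,4,6-trimethylphenyl gives a 1.4-fold lower number from compound 2 to compound 3 (0.13 log units; within the scatter), so these two substituted rings cannot be told apart here. Compound 1 carries a limit of the assay and not a number, which leaves the step from it without an upper end: the limit of > 50000 nM in this assay, at which 1 of the 3 values shown sits.

From the compounds shown here alone, whether a ring bearing an amine or a carboxylic acid would read the same at this position remains open, as does the effect of a chlorine atom there.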